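The source may report more compounds than this note shows. Statements on the series, on what has been measured and on what is new or still open speak of the compounds shown alone.

Compound 1 `O=C(C1CCC(C(F)(F)F)CC1)N1CC(c2nc(-c3cccc(F)c3)no2)C1`: in an assay on HEK293 cells for negative allosteric modulation of metabotropic glutamate receptor 5 (Homo sapiens), read by FLIPR (on this read-out higher numbers stand for weaker inhibition and lower numbers for stronger inhibition), compound 1 gives > 10000 nM, which is a limit of the assay rather than a number.
Compound 2 `Cc1cccc(-c2noc(C3CN(C(=O)C4CCC(C(F)(F)F)CC4)C3)n2)c1`: in this assay compound 2 gives > 10000 nM, again a limit.
Compound 3 `Cc1ccc(C(=O)N2CC(c3nc(-c4cccc(F)c4)no3)C2)cc1`: in this assay compound 3 gives > 10000 nM, also a limit.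

All three measured values sit at the limit of > 10000 nM in this assay, at which 3 of the 3 values shown sit, so none of them can be set in order against the others. The change from compound 2 to compound 1 is fluoro in place of methyl on an aromatic carbon, and its step is a step that the two limits leave unreadable from compound 2 to compound 1. The unmeasured compound 4 `O=C(c1ccc(F)cc1)N1CC(c2nc(-c3cccc(F)c3)no2)C1` arises from compound 3 by fluoro in place of methyl on an aromatic carbon. This is the same kind of change, not the same one: in compound 2 the place is meta to a large group, in compound 3 it is para to a large group. How the core of compound 3 differs from the core of compound 2 is not broken down here. For compound 4 the expected step that the limit leaves unreadable from compound 3 to compound 4 in this assay is small, since compound 3 gives > 10000 nM and compound 1 gives > 10000 nM, both limits. Compound 4 is therefore estimated at 15000 nM, most likely again reported only as a limit.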

Compound 4, half-maximal inhibitory concentration: > 10000 nM
Compound 4 was reported as a limit (the forecaster's own chance of this, stated with the estimate: 80%); the middle value does not contradict the limit.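

Compound 4, like compound 3, is reported only as a limit, so the step between them cannot be read, and fluoro in place of methyl gets no size here: the limit of > 10000 nM in this assay, at which 4 of the 4 values shown sit.

The compounds shown leave open what size this change has when both partners give real numbers in this assay, and which structures would give such numbers.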